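From Fluorine to Chlorine on a Series at the Limit

The source may hold more compounds than are shown below. What is called first, only, known or untested is meant among the compounds shown, and "the series" means these compounds.

Of the compounds shown here, two built on a shared core have been tested in a functional assay on HL-60 cells (Homo sapiens) for antiproliferative activity, read by MTT assay, with a stated time of 72 h; a lower number here means a stronger inhibitor, a higher number a weaker inhibitor. Compound 1, `COc1cc(-n2ncnc2-c2ccc(F)cc2)cc(OC)c1OC`, carries a 4-fluorophenyl group. In this assay compound 1 gives only a limit, > 10000 nM. Compound 2, `COc1cc(-n2ncnc2-c2cccc(F)c2)cc(OC)c1OC`, carries a 3-fluorophenyl group instead. In this assay compound 2 also gives only a limit, > 10000 nM. For the measured compounds named here, the one measured step, a step that the two limits leave unreadable from compound 1 to compound 2, cannot be sized, since (the limit of > 10000 nM in this assay, at which 2 of the 2 values shown sit). Compound 2 therefore stands at the limit of this assay, with no number beneath it that could be compared against anything else.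

Compound 3, `COc1cc(-n2ncnc2-c2ccc(Cl)cc2)cc(OC)c1OC`, is not yet measured. It differs from compound 2 in one place: 4-chlorophenyl in place of 3-fluorophenyl on an aromatic carbon. Because the limit of > 10000 nM in this assay, at which 2 of the 2 values shown sit, holds for both measured compounds, there is no readable step that would point toward a gain or a loss from this change. No movement beyond the scatter is expected, and the expected step is a step that the limit leaves unreadable from compound 2 to compound 3. Compound 3 is estimated to give about 20000 nM in this assay, within a range from 5000 nM to 80000 nM, most probably appearing again as a limit rather than a number.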

Compound 3, half-maximal inhibitory concentration: > 10000 nM
Compound 3: no number, only a limit; the forecaster's own chance of this, stated with the estimate: 75%; the middle value is on the limit's open side.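

Compound 3, like compound 1 and compound 2, gives only a limit in this assay, so none of the steps among these three compounds can be read: the limit of > 10000 nM in this assay, at which 3 of the 3 values shown sit. The compounds shown leave open whether any group in this position on the shared core would give an actual number in this assay.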